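This account rests on a few compounds, and the source may have more. Where it says the series, first, only, none or still open, it means among the compounds named here.

Measured compounds:
compound 1, `Cc1cccc(Cn2cc(COc3ccc4c(=O)ccoc4c3)nn2)c1` — 20300 nM
compound 2, `O=c1ccoc2cc(OCc3cn(Cc4ccccc4Br)nn3)ccc12` — > 100000 nM

In a functional assay on A549 cells (Homo sapiens) for cytotoxicity, read by MTT assay, with a stated time of 48 h (a higher number here means a weaker inhibitor, a lower number a stronger inhibitor), compound 2 returns only a limit, > 100000 nM; the reading sits at the limit of > 100000 nM in this assay, at which 1 of the 2 values shown sits. Compound 1 gives 20300 nM in this assay. For the measured compounds named here, the one measured step ran an at least 4.9-fold higher number from compound 1 to compound 2 (0.69 log units; beyond the scatter). Compound 3, `N#Cc1cccc(Cn2cc(COc3ccc4c(=O)ccoc4c3)nn2)c1`, differs from compound 2 by 3-cyanophenyl in place of 2-bromophenyl on a saturated chain carbon bound to an aromatic nitrogen. That step replaced a 3-methylphenyl with a 2-bromophenyl and weakened the series; the present change again places a 3-substituted phenyl, as in compound 1, so a return toward that level is expected. For compound 3 the estimate in this assay is 40000 nM, range 15000 nM to 110000 nM. The expected step is an at least 2.5-fold lower number from compound 2 to compound 3 (0.39 log units; beyond the scatter).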

Compound 3, half-maximal inhibitory concentration: 14300 nM
The estimate for compound 3 lay 2.8-fold (0.45 log units) above the measured number; measured number below the stated range.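

In this assay, 3-cyanophenyl in place of 2-bromophenyl at this position gives an at least 6.9-fold lower number from compound 2 to compound 3 (0.84 log units; beyond the scatter). The reading for compound 2 is only a limit, so the full size of that step stays unknown: the limit of > 100000 nM in this assay, at which 1 of the 3 values shown sits.

Cyano in place of methyl on an aromatic carbon gives a 1.4-fold lower number from compound 1 to compound 3 (0.15 log units; within the scatter), so this pair does not separate 3-cyanophenyl from 3-methylphenyl.

Still open, as far as these compounds go, is whether a 3-bromophenyl group would read like 2-bromophenyl or like the other two groups. From the compounds shown here alone, the reading for a 3-aminophenyl or 3-carboxyphenyl group also remains open.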